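The compounds below may be only part of what the source reports. "The series", "measured", "known", "first", "only" and "open" are said of these compounds alone.

Within the data shown here, in an ADME assay on the whole organism for metabolic stability, with Rattus norvegicus as the target (a higher number here means that the compound lasts longer, a lower number that the compound disappears faster), compound 1 `O=S(=O)(c1ccc(O)c2ncccc12)C1CCCC1` gives 0.18 h, while compound 2 `O=S(=O)(c1cc(Cl)c(O)c2ncccc12)C1CCCC1` gives 11 h, the higher of the two numbers so far. The two differ by a chloro in place of hydrogen on an aromatic carbon, and the result is a 61-fold higher number from compound 1 to compound 2 (1.79 log units; beyond the scatter), a large step well beyond the scatter.

Compound 3 `O=S(=O)(c1cc(Cl)c(O)c2ncccc12)N1CCCC1` keeps that chloro and changes a different place, with pyrrolidin-1-yl in place of cyclopentyl on a sulfonyl sulfur. Among the measured compounds shown here, the one measured step bears on this change only indirectly. It shows how much a single replacement can move the number, but it concerns the chloro and not the group on the sulfonyl sulfur. For the measured compounds named here, no measured pair shows the effect of the new replacement.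

The best starting point is therefore compound 2 at 11 h, since compound 3 shares its chloro. The step expected in this assay is a 1.6-fold lower number from compound 2 to compound 3 (0.20 log units; within the scatter), a modest fall that stays within the scatter, though the uncertainty is wide. Compound 3 is estimated at 7 h, with an expected range of 2 h to 16 h.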

Compound 3, half-life: 8.6 h
Compound 3: middle estimate off by 1.2-fold (0.09 log units), on the low side; the measured number falls inside the stated range.
By their numbers in this assay, from the lowest: compound 1; then compounds 3 and 2 (each within the scatter of the next).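

In this assay, pyrrolidin-1-yl in place of cyclopentyl on a sulfonyl sulfur gives a 1.3-fold lower number from compound 2 to compound 3 (0.11 log units; within the scatter), so compound 2 and compound 3 cannot be told apart by this measurement. Among these compounds, this is the first measured change at this place, and it shows that a ring of the same size, with the same count of heavy atoms but with one nitrogen among them, leaves the half-life within the scatter, whereas the earlier step showed only what a single replacement on an aromatic carbon can do. No measured information is available to explain why the number holds steady across this replacement.

The compounds shown leave open whether pyrrolidin-1-yl would give the same result with hydrogen in place of the chloro, on the core of compound 1. They also leave open how other groups on the sulfonyl sulfur, such as a morpholine ring, a dimethylamino group or an open butyl chain, would compare with cyclopentyl and pyrrolidin-1-yl, and whether a fluoro or a methyl could stand in for the chloro.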